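This account rests on a few compounds, and the source may have more. Where it says the series, first, only, none or still open, it means among the compounds named here.

Compound 1 `Cc1nn(Cc2ccc(C(N)=O)cc2)c(C)c1NC(=O)c1ccc(COc2ccccc2)cc1`: > 100000 nM
Compound 2 `CNC(=O)c1cccc(Cn2nc(C)c(NC(=O)c3ccc(COc4ccccc4)cc3)c2C)c1`: 6200 nM

In a functional assay on MIA PaCa-2 cells (Homo sapiens) for antiproliferative activity, read by MTT assay, with a stated time of 72 h (a higher number here means that more compound is needed for the effect, a lower number that less compound is needed), compound 1 gives > 100000 nM, which is a limit of the assay and not a number, as the limit of > 100000 nM in this assay, at which 1 of the 2 values shown sits, records. For the measured compounds named here, compound 2 gives 6200 nM, the only true number so far. Compound 3 `CNC(=O)c1cccc(Cn2nc(C)c(NC(=O)c3ccc(COc4ccccc4Cl)cc3)c2C)c1` turns the phenoxy of compound 2 into 2-chlorophenoxy, with chloro in place of hydrogen on an aromatic carbon. Going by the values given here, the one measured step, an at least 16-fold lower number from compound 1 to compound 2 (1.20 log units; beyond the scatter), was large but changed another part of the molecule, so it offers no direct guide here. A small shift toward a lower number is expected, estimated as a 1.8-fold lower number from compound 2 to compound 3 (0.25 log units; within the scatter). For compound 3 the estimate is 3500 nM, with an expected range of 1000 nM to 15000 nM.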

Compound 3, half-maximal effective concentration: 6300 nM
For compound 3 the middle estimate is 1.8-fold (0.26 log units) below the measured one, and the stated range covers the measured number.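

In this assay, chloro in place of hydrogen on an aromatic carbon, ortho to a large group, gives a 1.0-fold higher number from compound 2 to compound 3 (0.01 log units; within the scatter) and so leaves compound 3 level with compound 2. For the compounds shown here, this is the first reading at the phenoxy end of the molecule, since the earlier step changed another part. At this position, on this evidence, a single chloro is accepted with no shift beyond the scatter, though compound 3 gains nothing from it.

On these data alone, whether a larger group here, such as methoxy, an amine or a carboxylic acid, would read the same remains open. Nothing measured in this set bears on why the chloro step reads as it does.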